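This account rests on a few compounds, and the source may have more. Where it says the series, first, only, none or still open, it means among the compounds named here.

In a functional assay on NCI-H2286 cells (Homo sapiens) for antiproliferative activity, read by CCK-8 assay, with a stated time of 72 h (a lower number here means a stronger inhibitor, a higher number a weaker inhibitor), compound 1 `Cc1ccc(C(=O)Nc2cccc(C(F)(F)F)c2)cc1-c1ccc2c(-c3cn[nH]c3)n[nH]c2c1` gives > 1000 nM, which is a limit of the assay. Within the data shown here, compound 2 `Cc1ccc(C(=O)Nc2cccc(C(F)(F)F)c2)cc1-c1ccc2c(-c3cnn(C4CC4)c3)n[nH]c2c1` gives 93 nM, the only actual number so far. Cyclopropyl in place of hydrogen on an aromatic nitrogen accounts for an at least 10-fold lower number from compound 1 to compound 2 (1.03 log units; beyond the scatter), a large step. Compound 3 `Cc1ccc(C(=O)Nc2cccc(C(F)(F)F)c2)cc1-c1ccc2c(-c3cnn(CC(=O)N(C)C)c3)n[nH]c2c1` has (dimethylcarbamoyl)methyl in place of that cyclopropyl ((dimethylcarbamoyl)methyl in place of cyclopropyl on an aromatic nitrogen). Among the measured compounds shown here, the step to compound 2 is the only guide, and it replaced hydrogen rather than one group with another, so only a slight rise in the number is expected, within the scatter: a 1.6-fold higher number from compound 2 to compound 3 (0.21 log units; within the scatter). For compound 3 the estimate is 150 nM, with an expected range of 40 nM to 600 nM.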

Compound 3, half-maximal inhibitory concentration: > 1000 nM
Compound 3: only a limit was reported; the forecaster's own chance of this, stated with the estimate: 10%; middle value at least 6.6-fold (0.82 log units) from the limit.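

Putting a group on this aromatic nitrogen does not by itself bring activity: (dimethylcarbamoyl)methyl in place of cyclopropyl gives an at least 10-fold higher number from compound 2 to compound 3 (1.03 log units; beyond the scatter). The outcome therefore depends on which group sits there, not merely on the hydrogen being replaced. The result for compound 3 is a limit, and the step between compound 1 and compound 3 cannot be read, as both results are limits: the limit of > 1000 nM in this assay, at which 2 of the 3 values shown sit.

Cyclopropyl is the only group here with an actual number. On these data alone, whether a methyl, an ethyl or a cyclobutyl would keep that activity remains open.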